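The compounds below may be only part of what the source reports. "The series", "measured", "known", "first", "only" and "open" are said of these compounds alone.

Measured compounds:
- compound 1, `COc1cc(-c2cc(/C=C/C(=O)c3ccc(Cl)c(Cl)c3)[nH]n2)cc(OC)c1OC`: -10%
- compound 2, `COc1ccc(-c2cc(/C=C/C(=O)c3ccc(N)cc3)[nH]n2)cc1OC`: -96%
- compound 3, `COc1ccc(-c2cc(/C=C/C(=O)c3cc(OC)c(OC)c(OC)c3)[nH]n2)cc1OC`: -94%

In a functional assay on UACC-257 cells (Homo sapiens) for cytotoxicity, read by sulforhodamine B assay, with a stated time of 48 h, tested at 100 uM (a lower number here means a stronger effect, a higher number a weaker effect of the compound at the concentration tested), compound 1 gives -10%, the highest of the three numbers, so the weakest effect at the concentration tested. Compound 3 gives -94% and compound 2 gives -96%; both lie far below compound 1, beyond the scatter. Going by the values given here, compounds 2 and 3 differ from compound 1 at more than one place, so no single-change step is available between the measured compounds.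

Compound 4, `COc1cc(-c2cc(/C=C/C(=O)c3ccc(F)c(F)c3)[nH]n2)cc(OC)c1OC`, is the next compound to be measured in this assay. It differs from compound 1 in one place:
3,4-difluorophenyl in place of 3,4-dichlorophenyl on a carbonyl carbon
The shared core and the chain with the carbonyl are unchanged. Among the compounds with values here, with no measured single-change step to lean on, the expected step from compound 1 to compound 4 is a number 10 percentage points lower from compound 1 to compound 4 (within the scatter), a modest shift toward a stronger effect, though possibly none beyond the scatter. The expected value for compound 4 is -20%, with a range from -60% to 5%.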

Compound 4, a percentage reported as activity, at one concentration (the size of the read-out at that concentration, not a potency): -37%
Estimate against measurement, compound 4: 17 percentage points above; the range from low to high includes it.
By their numbers in this assay, from the lowest: compounds 2 and 3 (each within the scatter of the next); then compound 4; then compound 1.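

In this assay, going by these compounds alone, the phenyl on the carbonyl carbon gives the first single change that can be read: 3,4-difluorophenyl in place of 3,4-dichlorophenyl produces a number 27 percentage points lower from compound 1 to compound 4 (beyond the scatter), with the shared core and the chain with the carbonyl untouched. This position therefore responds to the choice of halogen, even though the heavy-atom count, the ring and the donor and acceptor counts of the group stay the same. Nothing measured here bears on why the step occurs.

On these data alone, whether the trend extends to a phenyl carrying no halogen, or to an amine or a carboxylic acid on that phenyl, remains open. Within the data shown here, compound 2 and compound 3 differ from compound 4 in more than one place, so no step to either can be read, and their values say nothing about this position alone.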